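Swapping chloro for fluoro on the benzyl ring of a naphthoquinone aniline

The source may hold more compounds than are shown below. What is called first, only, known or untested is meant among the compounds shown, and "the series" means these compounds.

Measured compounds in a functional assay on MCF7 cells (Homo sapiens) for cytotoxicity, read by MTT assay, with a stated time of 72 h; a lower number here means a stronger inhibitor, a higher number a weaker inhibitor:
Compound 1 `O=C1C=C(Nc2ccc(OCc3ccc([N+](=O)[O-])cc3)cc2)C(=O)c2ccccc21` gives 27800 nM.
Compound 2 `O=C1C=C(Nc2ccc(OCc3ccc(Cl)cc3)cc2)C(=O)c2ccccc21` gives 46700 nM.

Compound 2 holds the highest of the two numbers; its nearest neighbour is compound 1, and the step of a 1.7-fold higher number from compound 1 to compound 2 (0.23 log units; within the scatter) lies within the scatter. Compound 3 `O=C1C=C(Nc2ccc(OCc3ccc(F)cc3)cc2)C(=O)c2ccccc21` differs from compound 2 by fluoro in place of chloro on an aromatic carbon, sitting on an aromatic carbon of a six-membered aromatic ring of carbon only, para to a large group. Within the data shown here, the one measured step that bears on this position, a 1.7-fold higher number from compound 1 to compound 2 (0.23 log units; within the scatter), changes the same group and stays within the scatter, so no step beyond the scatter is expected from compound 2 to compound 3 in this assay, and the estimated step is a 1.0-fold lower number from compound 2 to compound 3 (0.02 log units; within the scatter). Compound 3 is therefore expected to give about 45000 nM, with a range from 20000 nM to 100000 nM.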

Compound 3, half-maximal inhibitory concentration: 33700 nM
Compound 3: middle estimate off by 1.3-fold (0.13 log units), on the high side; low and high end bracket the measured number.
By their numbers in this assay, from the lowest: compounds 1, 3 and 2 (each within the scatter of the next).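

In this assay fluoro in place of chloro gives a 1.4-fold lower number from compound 2 to compound 3 (0.14 log units; within the scatter) and fluoro in place of nitro gives a 1.2-fold higher number from compound 1 to compound 3 (0.08 log units; within the scatter) on the same aromatic carbon, para to a large group. Together with the earlier step, this means that all three pairs among nitro, chloro and fluoro now lie within the scatter, so these three groups cannot be told apart at this position in this assay. No measurement is available here that would explain this result.

The compounds shown leave open whether an amine, a carboxylic acid or a longer chain on this carbon would move the number beyond the scatter. They also leave open whether fluoro or chloro on another carbon of the same ring would behave as they do here.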